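The compounds below may be only part of what the source reports. "The series", "measured", "known", "first", "only" and "open" are said of these compounds alone.

In an ADME assay on MT4 cells (Homo sapiens) for cytotoxicity (on this read-out lower numbers stand for higher toxicity in this test and higher numbers for lower toxicity in this test), compound 1 `Cc1cc(C)cc(Cn2c(SCC(=O)Nc3ccc(C)cc3Cl)nc3ccc(Cl)cc32)c1`, with a 3,5-dimethylbenzyl group on an aromatic nitrogen, gives 79300 nM as its half-maximal cytotoxic concentration. Compound 2 `Cc1cc(C)cc(S(=O)(=O)n2c(SCC(=O)Nc3ccc(C)cc3Cl)nc3ccc(Cl)cc32)c1` carries (3,5-dimethylphenyl)sulfonyl in that place. For compound 2 the reading is only a limit, > 234000 nM in this assay, and not a number. Compound 3 `Cc1cc(C)cc(S(=O)(=O)n2c(SCC(=O)Nc3ccc(S(C)(=O)=O)cc3Cl)nc3ccc(Cl)cc32)c1` keeps that sulfonyl group and changes elsewhere, with methylsulfonyl in place of methyl on an aromatic carbon on an aromatic carbon. Among the compounds with values here, the only measured step, an at least 2.9-fold higher number from compound 1 to compound 2 (0.46 log units; beyond the scatter) and beyond the scatter, concerns the group on the aromatic nitrogen, so it does not bear directly on this change and no step beyond the scatter is expected in this assay here. The estimated change is an at least 1.2-fold lower number from compound 2 to compound 3 (0.09 log units; that floor lies within the scatter) on this expectation. For compound 3 the expected value is 190000 nM with an estimated range from 70000 nM to 260000 nM in all.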

Compound 3, half-maximal cytotoxic concentration: 3590 nM
The estimate for compound 3 lay 53-fold (1.72 log units) above the measured number; the measured number lies below the stated range.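

In this assay, methylsulfonyl in place of methyl on the aromatic carbon para to a large group gives an at least 65-fold lower number from compound 2 to compound 3 (1.81 log units; beyond the scatter) and so moves compound 3 towards higher toxicity in this test. Compound 1 and compound 2 differ only in the group on the aromatic nitrogen, so they said nothing about this carbon, which now proves far from indifferent to what it carries. The step starts from a limit and not a number, since compound 2 has no exact reading: the limit of > 234000 nM in this assay, at which 1 of the 3 values shown sits.

As far as these compounds go, whether the change belongs to methylsulfonyl itself or would also follow from another group on this carbon, such as an amine, a nitrile or a carboxylic acid, stays open. Also open, from the compounds shown here alone, is whether the same change would have a similar effect with the 3,5-dimethylbenzyl group of compound 1 on the aromatic nitrogen.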